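Pyrazole sulfonamides: acetyl on the sulfonamide nitrogen

This account rests on a few compounds, and the source may have more. Where it says the series, first, only, none or still open, it means among the compounds named here.

Measured compounds in a functional assay on cells (Cancer cell lines, Homo sapiens) for cytotoxicity, read by sulforhodamine B assay, with a stated time of 48 h; a higher number here means a weaker inhibitor of growth, a lower number a stronger inhibitor of growth:
compound 1 `COc1ccc(OC)c(-c2cc(-c3ccccc3)nn2-c2ccc(S(=O)(=O)NC(C)=O)cc2)c1` gives 9700 nM;
compound 2 `NS(=O)(=O)c1ccc(-n2nc(-c3ccccc3)cc2-c2cc(O)ccc2O)cc1` gives 83900 nM.

Going by the values given here, compound 2 stands with the highest number of the two; its neighbour compound 1 lies well below it, beyond the scatter, and the two differ in more than one place, so no single step connects them.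

Compound 3 `CC(=O)NS(=O)(=O)c1ccc(-n2nc(-c3ccccc3)cc2-c2cc(O)ccc2O)cc1` differs from compound 2 by acetyl in place of hydrogen on a sulfonamide nitrogen. Compound 1 also carries the acetyl group, but with other changes beside it, so its lower number cannot be read as the effect of the acetyl alone. The expectation for compound 3 is a moderate step downward in this assay, of about a 2.8-fold lower number from compound 2 to compound 3 (0.45 log units; beyond the scatter), though a step within the scatter would not surprise. Compound 3 is estimated at 30000 nM, in the range 8000 nM to 100000 nM.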

Compound 3, concentration for 50% growth inhibition: 91300 nM
Compound 3: the middle estimate sits 3.0-fold (0.48 log units) below what was measured, within the range that was stated.
By their numbers in this assay, from the lowest: compound 1; then compounds 2 and 3 (each within the scatter of the next).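

In this assay, acetyl in place of hydrogen on the sulfonamide nitrogen, with 2,5-dihydroxyphenyl held constant, gives only a 1.1-fold higher number from compound 2 to compound 3 (0.04 log units; within the scatter). With acetyl held constant, 2,5-dihydroxyphenyl in place of 2,5-dimethoxyphenyl on an aromatic carbon gives a 9.4-fold higher number from compound 1 to compound 3 (0.97 log units; beyond the scatter), so among these compounds the difference follows that aromatic substituent, not the sulfonamide nitrogen. No available measurement accounts for either step. Open: whether acetyl behaves the same way alongside 2,5-dimethoxyphenyl, and whether a longer acyl chain or an amine on the sulfonamide nitrogen would shift the number.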